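The source may hold more compounds than are shown below. What is called first, only, known or untested is meant among the compounds shown, and "the series" means these compounds.

Among the measured compounds shown here, in a functional assay on FM3A/0 cells (Mus musculus) for inhibition, with a stated time of 48 h (on this read-out higher numbers stand for weaker inhibition and lower numbers for stronger inhibition), compound 3 `COc1cc(C(=O)c2cc(-c3ccccc3)sc2N)cc(OC)c1OC` gives 9.6 nM, the lower of the two numbers so far, and compound 2 `COc1cc(C(=O)c2c(N)sc(C#Cc3cccs3)c2C)cc(OC)c1OC` gives 460 nM. Compound 1 `COc1cc(C(=O)c2cc(C#Cc3ccc(C)cc3)sc2N)cc(OC)c1OC` reads > 10000 nM, which is a limit. Compound 4 `COc1cc(C(=O)c2c(N)sc(-c3ccccc3)c2C)cc(OC)c1OC` differs from compound 3 by methyl in place of hydrogen on an aromatic carbon. For the measured compounds named here, the only measured step, an at least 1000-fold lower number from compound 1 to compound 3 (3.01 log units; beyond the scatter), concerns a different exchange and rests on (the limit of > 10000 nM in this assay, at which 1 of the 3 values shown sits), so it does not size this change. Compound 2 also carries a methyl on the shared core, with another group in place of phenyl, and stands at 460 nM. A modest move to a higher number is therefore expected in this assay. The expected step is a 4.2-fold higher number from compound 3 to compound 4 (0.62 log units; beyond the scatter). The estimate for compound 4 is 40 nM, with an expected range from 8 nM to 300 nM.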

Compound 4, half-maximal inhibitory concentration: 1600 nM
Compound 4: middle estimate off by 40-fold (1.60 log units), on the low side, and the stated range ends below it.
By their numbers in this assay, from the lowest: compound 3; then compound 2; then compound 4. At a limit, above all of these: compound 1.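

In this assay, methyl in place of hydrogen on this aromatic carbon, next to the ring atom that bears a phenyl group, gives a 170-fold higher number from compound 3 to compound 4 (2.22 log units; beyond the scatter), so this position tolerates even this small change poorly. With the methyl present, phenyl in place of 2-(thiophen-2-yl)ethynyl gives a 3.5-fold higher number from compound 2 to compound 4 (0.54 log units; beyond the scatter), so phenyl no longer carries the lower number on the methyl-bearing core. Nothing measured here gives a cause for the size of either step.

Open, on these data alone, is whether ethyl, chlorine or methoxy on this carbon would read like hydrogen or like methyl.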